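The source may hold more compounds than are shown below. What is called first, only, known or untested is meant among the compounds shown, and "the series" means these compounds.

For the measured compounds named here, compound 3 `CC(C)NC(=O)NS(=O)(=O)c1cc(C#N)ccc1Oc1ccc(Cl)cc1` gives 8490 nM in a functional assay on HEK293 cells for antagonist activity at thromboxane A2 receptor (Homo sapiens), read by fluorescence and calcium flux (a higher number here means a weaker inhibitor, a lower number a stronger inhibitor), the second highest of the three numbers measured so far. Its nearest neighbour is compound 2 `CC(C)NC(=O)NS(=O)(=O)c1cc(C#N)ccc1Oc1ccc(F)cc1` with 9300 nM, and the furthest is compound 1 `Cc1ccccc1Oc1ccc(C#N)cc1S(=O)(=O)NC(=O)NC(C)C` with 6130 nM; all three lie within the scatter of one another. The step that bears most on the next compound is a 1.1-fold lower number from compound 2 to compound 3 (0.04 log units; within the scatter), a swap of one halogen for another on the same aromatic carbon. The steps of a 1.5-fold higher number from compound 1 to compound 2 (0.18 log units; within the scatter) and a 1.4-fold higher number from compound 1 to compound 3 (0.14 log units; within the scatter) point the same way: none of these changes moved this assay beyond its scatter. Compound 4 `CC(C)NC(=O)NS(=O)(=O)c1cc(C#N)ccc1Oc1ccc(Br)cc1` differs from compound 3 by bromo in place of chloro on an aromatic carbon. No step beyond the scatter is expected, so a 1.1-fold lower number from compound 3 to compound 4 (0.03 log units; within the scatter) is anticipated, and compound 4 is estimated at 8000 nM, within a range from 4000 nM to 16000 nM.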

Compound 4, half-maximal inhibitory concentration: 9130 nM
Estimate against measurement, compound 4: 1.1-fold (0.06 log units) below; the measured number falls inside the stated range.
By their numbers in this assay, from the lowest: compounds 1, 3, 4 and 2 (each within the scatter of the next).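

Bromo now joins fluoro and chloro on this aromatic carbon, para to a large group, and in this assay the steps of a 1.1-fold higher number from compound 3 to compound 4 (0.03 log units; within the scatter) and a 1.0-fold lower number from compound 2 to compound 4 (0.01 log units; within the scatter) stay within the scatter, so these three halogens cannot be told apart here. Against the 2-methylphenyl of compound 1, the 4-bromophenyl gives no readable difference either: a 1.5-fold higher number from compound 1 to compound 4 (0.17 log units; within the scatter). Nothing available explains this flat result. On these data alone, whether an amine, a carboxylic acid or a methoxy group on this carbon would move the number remains open.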